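Swapping diethylamino for piperidin-1-yl in a weakly cytotoxic pair

The source may report more compounds than this note shows. Statements on the series, on what has been measured and on what is new or still open speak of the compounds shown alone.

Compound 1, `N=C(N)Nc1ccc(N2CCCCC2)cc1`: 232000 nM
Compound 2, `CCN(CC)c1ccc(NC2=NCCN2)cc1`: > 444000 nM

Both compounds were tested in an ADME assay on L6 cells (Rattus norvegicus) for cytotoxicity; a lower number here means a stronger inhibitor, a higher number a weaker inhibitor. Compound 1 gives 232000 nM. For compound 2 the assay reports only a limit, > 444000 nM, not a number. Compound 2 therefore stands at the weak end of the numbers shown, as the limit of > 444000 nM in this assay, at which 1 of the 2 values shown sits, makes clear.

Compound 3, `c1cc(N2CCCCC2)ccc1NC1=NCCN1`, has not yet been measured. It differs from compound 2 in one place: piperidin-1-yl in place of diethylamino on an aromatic carbon. Compound 1 carries the same piperidin-1-yl group on its aromatic ring and also gives only a weak value, 232000 nM, so no large move is expected from this change. The step of an at least 1.2-fold lower number from compound 2 to compound 3 (0.10 log units; that floor lies within the scatter) is expected to stay within the usual scatter, with no clear direction. Compound 3 is estimated at 350000 nM, with a likely range from 150000 nM to 800000 nM, and a fair chance that the assay once more reports only a limit.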

Compound 3, half-maximal inhibitory concentration: > 283000 nM
Compound 3 ended at the assay's limit (the forecaster's own chance of this, stated with the estimate: 50%); the middle value lies beyond the limit too.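

In this assay, compound 2 and compound 3 are both reported only as limits, not numbers, and the step for piperidin-1-yl in place of diethylamino on an aromatic carbon cannot be read in either direction. Compound 3 does open a different comparison, with compound 1, which shares its piperidin-1-yl group: a group with a five-membered non-aromatic ring in place of a group with no ring, on a nitrogen on an aromatic ring, gives an at least 1.2-fold higher number from compound 1 to compound 3 (0.08 log units; that floor lies within the scatter). Only a floor is known for that step, so the true change may be small or large.

As far as these compounds go, the actual values of compound 2 and compound 3 remain unknown. Also open, from the compounds shown here alone, is whether a methoxy group or a carboxylic acid on that aromatic carbon would give a measured number rather than a limit.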